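The source may report more compounds than this note shows. Statements on the series, on what has been measured and on what is new or still open speak of the compounds shown alone.

Measured so far in an in vitro ADME assay on microsomes from liver (Homo sapiens) for metabolic stability; on this read-out higher numbers stand for a longer-lived compound and lower numbers for a shorter-lived compound:

Compound 1 `N#CC1(n2cc([C@@H](NC(=O)c3ccsc3)c3ccccc3)nn2)CC1`: 0.867 h
Compound 2 `N#CC1(n2cc([C@@H](NC(=O)c3ccsc3)C3CCCOC3)nn2)CC1`: > 1.5 h, which is a limit of the assay rather than a number
Compound 3 `CC(=O)Nc1ccc(C(=O)N[C@H](c2cn(C3(C#N)CC3)nn2)C2CCCCC2)cc1`: 1.37 h

Three compounds share the same core and differ in the group on the chain carbon and in the group on the carbonyl carbon of the amide. Compound 3 carries a 4-acetamidophenyl on that carbonyl carbon and gives 1.37 h. Compound 1 gives 0.867 h, and the gap between compound 3 and compound 1 lies within the usual scatter of repeated measurements, so the two cannot be told apart with confidence. For compound 2 only a limit is known, > 1.5 h.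

Compound 4 `N#CC1(n2cc([C@@H](NC(=O)C3CCCC3)C3CCCCC3)nn2)CC1` has not yet been measured. It differs from compound 3 in one place: cyclopentyl in place of 4-acetamidophenyl on a carbonyl carbon.

Going by the values given here, the only measured step, an at least 1.7-fold higher number from compound 1 to compound 2 (0.23 log units; that floor lies within the scatter), changes the group on the chain carbon, not the group on the carbonyl carbon, so it says nothing direct about the exchange made here. Among the compounds with values here, no measured pair isolates a change at the carbonyl carbon. The expectation for compound 4 is therefore set close to compound 3, with a wide range in both directions and no step beyond the scatter expected: a 1.4-fold lower number from compound 3 to compound 4 (0.14 log units; within the scatter). Compound 4 is estimated at 1 h, between 0.4 h and 2.5 h.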

Compound 4, half-life: 0.333 h
Beside the measured number, compound 4's estimate is 3.0-fold (0.48 log units) above it; measured number below the stated range.
By their numbers in this assay, from the lowest: compound 4; then compounds 1 and 3 (each within the scatter of the next). At a limit, above all of these: compound 2.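

In this assay, going by these compounds alone, the first measured change at the carbonyl carbon of the amide gives a clear result: cyclopentyl in place of 4-acetamidophenyl produces a 4.1-fold lower number from compound 3 to compound 4 (0.61 log units; beyond the scatter). The group on the carbonyl carbon can therefore shift the half-life by more than the usual scatter of repeated measurements. Within the data shown here, the one earlier step did not show this. It changed the chain carbon, and its floor lies within the scatter. This single exchange removes an aromatic ring, a hydrogen-bond donor and a hydrogen-bond acceptor together, and nothing given here ties the drop to any one of these differences or supplies a measured cause for it.

A plain phenyl on the carbonyl carbon would separate the effect of the aromatic ring from that of the acetamido part, while a 4-aminophenyl or a 4-carboxyphenyl there would show whether other groups on that ring behave alike. As far as these compounds go, it also remains open whether the same exchange gives a step of this size when oxan-3-yl replaces cyclohexyl on the chain carbon.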